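The source may hold more compounds than are shown below. What is called first, only, known or untested is meant among the compounds shown, and "the series" means these compounds.

Measured so far:
- compound 1, `C=C(C)C(=O)c1ccc(OC)cc1OC`: 29.8%
- compound 2, `CCOC(=O)c1nn(-c2ccccc2)c(-c2ccc(OC)cc2OC)c1-c1ccccc1`: 20.5%

In a functional assay on the whole organism (strain albino) for inhibition, with Rattus norvegicus as the target, read by paw edema, with stated times of 30 min and 2 h, at a dose of 25 mg/kg by the intraperitoneal route (on this read-out higher numbers stand for more inhibition at the one dose given (going by the name of the read-out) and lower numbers for less inhibition), compound 1 gives 29.8% and compound 2 gives 20.5%; the two numbers sit within the scatter of each other, so compound 2 cannot be placed above or below compound 1 on this read-out. Within the data shown here, no pair differing in one place has been measured, so no step size is known from the data.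

Compound 3, `CCOC(=O)c1nn(-c2ccccc2)c(-c2ccc(OC)cc2OC)c1C`, differs from compound 2 in one place: methyl in place of phenyl on an aromatic carbon. Among the measured compounds shown here, with no comparable step available, the expected change is none beyond the scatter, with a step of a number 1.5 percentage points higher from compound 2 to compound 3 (within the scatter). In this assay compound 3 is estimated at 22%, within 10% to 35%.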

Compound 3, a percentage reported as inhibition, in the whole organism at one dose (the size of the read-out at that dose, not a potency): 4.86%
Compound 3: middle estimate off by 17.1 percentage points, on the high side, and the stated range ends above it.
By their numbers in this assay, from the lowest: compound 3; then compounds 2 and 1 (each within the scatter of the next).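

In this assay, among these compounds, methyl in place of phenyl on this aromatic carbon gives a number 15.6 percentage points lower from compound 2 to compound 3 (beyond the scatter), the first step that can be read. This carbon of the shared core is therefore not indifferent to its group: inhibition at the one dose is kept better with phenyl than with methyl. Nothing at hand bears on the cause of this step.

Open, on these data alone, is whether an ethyl or propyl chain, a benzyl group or an amine on this carbon would give a number nearer that of phenyl or of methyl. Also open, as far as these compounds go, is how a phenyl carrying a methoxy group would compare with the plain phenyl here.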